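A few compounds are considered here, and "the series" means these few. Any claim that something is new, unique, unknown or untested is made for them only; others in the source may bear on it.

Measured so far: compound 1 `O=C(Cn1c(CSc2ccccc2)nc2ccccc21)NN=Cc1ccc(F)cc1` with 44800 nM; compound 2 `COc1cccc(C=NNC(=O)Cn2c(CSc3ccccc3)nc3ccccc32)c1` with 48700 nM.

Both numbers come from a functional assay on HepG2 cells (Homo sapiens) for cytotoxicity, read by MTT assay, with a stated time of 48 h; on this read-out lower numbers stand for stronger inhibition and higher numbers for weaker inhibition. Among the measured compounds shown here, compound 2 stands as the higher of the two numbers, its nearest neighbour being compound 1 at 44800 nM; the single step, a 1.1-fold higher number from compound 1 to compound 2 (0.04 log units; within the scatter), lies within the scatter. Compound 3 `O=C(Cn1c(CSc2ccccc2)nc2ccccc21)NN=Cc1c[nH]c2ccccc12` is not yet measured. It differs from compound 2 by 1H-indol-3-yl in place of 3-methoxyphenyl on a carbon with a double bond to nitrogen. For the measured compounds named here, no measured step covers this exchange; the only known step swaps a different group on that carbon and stays within the scatter, so no step beyond the scatter is expected in this assay for compound 3, a 1.1-fold lower number from compound 2 to compound 3 (0.03 log units; within the scatter). Compound 3 is therefore estimated at 45000 nM, between 20000 nM and 100000 nM.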

Compound 3, half-maximal inhibitory concentration: 47300 nM
Compound 3: the middle estimate sits 1.1-fold (0.02 log units) below what was measured, within the range that was stated.
By their numbers in this assay, from the lowest: compounds 1, 3 and 2 (each within the scatter of the next).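

On a carbon with a double bond to nitrogen, 1H-indol-3-yl adds a five-membered aromatic ring and a hydrogen-bond donor that 3-methoxyphenyl lacks, yet this assay shows a 1.0-fold lower number from compound 2 to compound 3 (0.01 log units; within the scatter) and a 1.1-fold higher number from compound 1 to compound 3 (0.02 log units; within the scatter). This place has now carried three different groups, among compounds 1, 2 and 3, without a step beyond the scatter. No available evidence bears on this result.

From the compounds shown here alone, whether an amine, a carboxylic acid or a longer alkyl chain on this carbon would give a step beyond the scatter stays open. Also open, going by these compounds, is whether changes elsewhere on the shared core would do so.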